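Swapping the oxadiazole aryl for a dimethoxypyrimidine

The source may report more compounds than this note shows. Statements on the series, on what has been measured and on what is new or still open speak of the compounds shown alone.

Measured so far:
compound 1 `C[C@H](c1ccccc1)N1C(=O)O[C@](Cc2ccccc2)(c2nnc(-c3ccccc3)o2)C1=O`, 82%
compound 2 `C[C@H](c1ccccc1)N1C(=O)O[C@](Cc2ccccc2)(c2nnc(-c3cc(F)cc(F)c3)o2)C1=O`, 74%

Both compounds were tested in an ADME assay (liver) for metabolic stability, with Liver microsome (Homo sapiens) as the target, using microsomes, with a stated time of 0.5 h, tested at 1 uM; on this read-out lower numbers stand for a less stable compound and higher numbers for a more stable compound. Compound 2 gives the lower of the two numbers, with compound 1 close by, and the step of a number 8 percentage points lower from compound 1 to compound 2 (within the scatter) lies within the scatter, so the two values cannot be told apart.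

Compound 3 `COc1cc(OC)nc(-c2nnc([C@@]3(Cc4ccccc4)OC(=O)N([C@H](C)c4ccccc4)C3=O)o2)n1` carries a different group on the same aromatic carbon: 4,6-dimethoxypyrimidin-2-yl in place of 3,5-difluorophenyl on an aromatic carbon. Going by the values given here, the only measured step that touches this position is the one from compound 1 to compound 2, and it was within the scatter. Among the compounds with values here, no measured step covers a change of this kind, so there is no basis for expecting a step beyond the scatter in either direction.

The estimate for compound 3 in this assay is therefore 70%, with a range from 50% to 88%, which corresponds to an expected step of a number 4 percentage points lower from compound 2 to compound 3 (within the scatter).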

Compound 3, percent of the compound remaining: 31%
The estimate for compound 3 lay 39 percentage points above the measured number; the measured number lies below the stated range.
By their numbers in this assay, from the lowest: compound 3; then compounds 2 and 1 (each within the scatter of the next).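

In this assay, the group on this aromatic carbon clearly can matter: 4,6-dimethoxypyrimidin-2-yl in place of 3,5-difluorophenyl gives a number 43 percentage points lower from compound 2 to compound 3 (beyond the scatter), and in place of phenyl it gives a number 51 percentage points lower from compound 1 to compound 3 (beyond the scatter). Compound 1 and compound 2 could not be told apart, so they showed only that adding the two fluorines to the phenyl ring left no readable mark, not that the position tolerates any aryl group. No measured evidence here explains the large drop.

The new group differs from phenyl in two ways at once, with ring nitrogens and two methoxy groups, and the compounds shown do not separate these two changes. Open, then, is where a plain pyrimidin-2-yl or a 3,5-dimethoxyphenyl group would stand on this read-out.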